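The compounds below may be only part of what the source reports. "The series", "measured", "known", "first", "only" and "open" are said of these compounds alone.

Series on a shared core, assessed in a functional assay on HepG2 cells (Homo sapiens) for cytotoxicity, read by MTT assay, with a stated time of 48 h; a lower number here means a stronger inhibitor, a higher number a weaker inhibitor. Compound 1 `CCCCCCCCNC(=O)[C@@H](NC(=O)c1cccs1)[C@@H](C)O` gives 149000 nM; compound 2 `CCCCCCCCNC(=O)[C@@H](NC(=O)/C=C/c1ccccc1)[C@@H](C)O` gives 55600 nM, the lowest of the two numbers, and the step of a 2.7-fold lower number from compound 1 to compound 2 (0.43 log units; beyond the scatter) lies beyond the scatter. Compound 3 `C/C=C/C=C/C(=O)N[C@H](C(=O)NCCCCCCCC)[C@@H](C)O` differs from compound 2 by prop-1-en-1-yl in place of phenyl on a double-bonded chain carbon bound to a double-bonded chain carbon. For the measured compounds named here, only one measured step exists, and it exchanges the whole acyl group rather than the phenyl alone, so it guides the present change weakly. For compound 3 a modest rise in number is expected, a 1.6-fold higher number from compound 2 to compound 3 (0.21 log units; within the scatter). Compound 3 is estimated at 90000 nM, range 35000 nM to 250000 nM.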

Compound 3, half-maximal inhibitory concentration: 102000 nM
Compound 3: the middle estimate sits 1.1-fold (0.05 log units) below what was measured; low and high end bracket the measured number.
By their numbers in this assay, from the lowest: compounds 2, 3 and 1 (each within the scatter of the next, the first and the last beyond it).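

In this assay, prop-1-en-1-yl in place of phenyl on a double-bonded chain carbon bound to a double-bonded chain carbon stays within the scatter (a 1.8-fold higher number from compound 2 to compound 3 (0.26 log units; within the scatter)). At this place, then, compound 3 keeps a number comparable to that of compound 2 without the six-membered aromatic ring. Penta-1,3-dien-1-yl in place of thiophen-2-yl on a carbonyl carbon also stays within the scatter (a 1.5-fold lower number from compound 1 to compound 3 (0.16 log units; within the scatter)). Going by these compounds, whether an amine or a carboxylic acid on the phenyl of compound 2 would shift the number beyond the scatter remains open. Nothing available accounts for these numbers.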